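This account rests on a few compounds, and the source may have more. Where it says the series, first, only, none or still open, it means among the compounds named here.

Working notes on the series. The shared core is that of compound 1 `C#CCOc1ccc(/C=C/C(C)=O)cc1OC`, which in a functional assay on HCT-116 cells (Homo sapiens) for antiproliferative activity, read by MTT assay, with a stated time of 48 h (on this read-out higher numbers stand for weaker inhibition and lower numbers for stronger inhibition), gives 49700 nM. Compound 3 `COc1cc(/C=C/C(C)=O)ccc1OCc1cn(-c2ccccc2Cl)nn1` gives 39000 nM in this assay; the values of compound 1 and compound 3 lie within the scatter of each other, so no order between them is read. Compound 2 `COc1cc(/C=C/C(C)=O)ccc1OCc1cn(-c2ccc(NC(=O)c3ccccc3)cc2)nn1` reaches only a limit of this assay, > 100000 nM, with no number behind it; this is the limit of > 100000 nM in this assay, at which 1 of the 3 values shown sits. Compound 4 `COc1cc(/C=C/C(C)=O)ccc1OCc1cn(-c2ccc(-c3ccccc3)cc2)nn1` is not yet measured; it differs from compound 2 in that (phenyl in place of benzamido on an aromatic carbon). For the measured compounds named here, no measured pair covers this change, so its size cannot be read from the series. Because compound 2 stands at > 100000 nM, the step to compound 4 can only be expected, not computed. The expected step is an at least 1.6-fold lower number from compound 2 to compound 4 (0.22 log units; that floor lies within the scatter), toward stronger inhibition or none beyond the scatter. Compound 4 is expected to give about 60000 nM, within 25000 nM to 150000 nM. This expectation rests on compound 1 at 49700 nM and compound 3 at 39000 nM, the two numbers the series provides.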

Compound 4, half-maximal inhibitory concentration: 65300 nM
Compound 4: middle estimate off by 1.1-fold (0.04 log units), on the low side; measured number inside the range.
By their numbers in this assay, from the lowest: compounds 3, 1 and 4 (each within the scatter of the next). At a limit, above all of these: compound 2.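

In this assay, for the compounds shown here, the exchange of benzamido for phenyl on this aromatic carbon, para to a large group, gives the first step that can be read at this position: an at least 1.5-fold lower number from compound 2 to compound 4 (0.18 log units; that floor lies within the scatter). With phenyl in this place the series holds a number where benzamido gave none, but the floor of the step does not establish a change beyond the scatter, and its full size stays unread. Compound 2 stands at a limit and not at a number: the limit of > 100000 nM in this assay, at which 1 of the 4 values shown sits.

The compounds shown leave open how an amine or a carboxylic acid on this carbon would read in this assay. Also open, from the compounds shown here alone, is whether the amide link of benzamido or its ring goes with the difference, which an acetamido group in the same place would help separate.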